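Propyl to Benzyl: An Estimate for Compound 4

The compounds below may be only part of what the source reports. "The series", "measured", "known", "first", "only" and "open" are said of these compounds alone.

Compound 1 `CN(C)C(=O)c1cccnc1NCCCN1CCN(c2ccccc2)CC1`: 6.31 nM
Compound 2 `CN(C)C(=O)c1cccnc1NCCCN1CCN(c2ccccc2OC(F)(F)F)CC1`: 3.16 nM
Compound 3 `CCCc1ccccc1N1CCN(CCCNc2ncccc2C(=O)N(C)C)CC1`: 0.2 nM

All three were tested in a functional assay for antagonist activity at Alpha-1A adrenergic receptor (Oryctolagus cuniculus) (on this read-out lower numbers stand for tighter binding and higher numbers for weaker binding), and share one core, differing only in the group carried on one aromatic carbon. Compound 3 gives the lowest number of the three: the step of a 32-fold lower number from compound 1 to compound 3 (1.50 log units; beyond the scatter) and the step of a 16-fold lower number from compound 2 to compound 3 (1.20 log units; beyond the scatter) are both beyond the scatter, whereas the step of a 2.0-fold lower number from compound 1 to compound 2 (0.30 log units; within the scatter) is within it. On these numbers compound 3 is the most potent of the set.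

Compound 4 `CN(C)C(=O)c1cccnc1NCCCN1CCN(c2ccccc2Cc2ccccc2)CC1` has not yet been measured in this assay. It differs from compound 3 by phenyl in place of ethyl on a saturated chain carbon bound to an aromatic carbon. For the measured compounds named here, no measured step involves a benzyl or a phenyl at that place, so the only guides are the two large steps that lead to compound 3. As far as these compounds go, both show that a propyl on that aromatic carbon gives a much lower number than hydrogen or trifluoromethoxy; whether a benzyl behaves like the propyl is unknown. The step from compound 3 to compound 4 is therefore expected to be modest, a 3.0-fold higher number from compound 3 to compound 4 (0.48 log units; beyond the scatter), toward a somewhat higher number. Compound 4 is accordingly estimated at 0.6 nM in this assay, within a range of 0.1 nM to 4 nM.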

Compound 4, dissociation constant: 6.31 nM
Beside the measured number, compound 4's estimate is 11-fold (1.02 log units) below it; measured number outside the range, above it.
By their numbers in this assay, from the lowest: compound 3; then compounds 2, 1 and 4 (each within the scatter of the next).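

In this assay, the low number of compound 3 does not carry over to every group joined to this aromatic carbon through a saturated chain carbon: phenyl in place of ethyl on that chain carbon undoes the whole gain seen with propyl (a 32-fold higher number from compound 3 to compound 4 (1.50 log units; beyond the scatter)). Benzyl also stands apart from neither hydrogen (no change at the digits printed from compound 1 to compound 4 (within the scatter)) nor trifluoromethoxy (a 2.0-fold higher number from compound 2 to compound 4 (0.30 log units; within the scatter)), so these three groups cannot be told apart on this read-out, and propyl alone is set apart from the others by steps beyond the scatter. Thus the earlier picture of a large step from adding a carbon group at this place holds for propyl but not for benzyl, and nothing available explains the contrast between them.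

The compounds shown leave open how narrow the requirement at this position is, since a butyl chain, an isopropyl group or a cyclopropyl ring could fall on either side of the contrast between propyl and benzyl. They also leave open whether a phenyl ring set further out on a longer chain, as in phenethyl, would read like benzyl or like propyl.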